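Ketone aryl swap in compound 1: cytotoxicity notes

The source may hold more compounds than are shown below. What is called first, only, known or untested is meant among the compounds shown, and "the series" means these compounds.

Compound 1 `O=C(/C=C/c1ccc2c(c1)B(O)OC2)c1ccco1` carries furan-2-yl on the carbonyl carbon. In an ADME assay on L929 cells (Mus musculus) for cytotoxicity, read by resazurin assay, with a stated time of 72 h (a lower number here means a stronger inhibitor, a higher number a weaker inhibitor), compound 1 gives only a limit, > 10 ug/mL, with no number behind it. For the measured compounds named here, the single numbered value in the set comes from compound 2 `COc1ccc(C(=O)/C=C/c2ccc3c(c2)B(O)OC3)c(OC)c1`, which in this assay gives 7.87 ug/mL. Going by the values given here, compound 1 thus sits at the limit of > 10 ug/mL in this assay, at which 1 of the 2 values shown sits, and no step between measured compounds can be drawn from the pair; the two values show compound 2 with a number where compound 1 has none.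

Compound 3 `O=C(/C=C/c1ccc2c(c1)B(O)OC2)c1ccc(Cl)cc1` differs from compound 1 in one place: 4-chlorophenyl in place of furan-2-yl on a carbonyl carbon. Among the compounds with values here, with no measured step of this kind to lean on, the expected step of an at least 1.2-fold lower number from compound 1 to compound 3 (0.09 log units; that floor lies within the scatter) is small, toward somewhat stronger inhibition, and may not clear the scatter. For compound 3 the expected value in this assay is 8 ug/mL, with a range from 3 ug/mL to 25 ug/mL, and a real chance that only a limit is returned again.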

Compound 3, half-maximal inhibitory concentration: > 10 ug/mL
Compound 3: only a limit was reported; the forecaster's own chance of this, stated with the estimate: 40%; middle value at least 1.2-fold (0.09 log units) away from the limit.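

Like compound 1, compound 3 gives only a limit in this assay, > 10 ug/mL, so no step between compound 1 and compound 3 can be read. The compounds shown leave open how 4-chlorophenyl and furan-2-yl on a carbonyl carbon compare in this assay.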